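Hydrazone Inhibitors in a Spectrophotometric Assay: Predicting Compound 4

The source may hold more compounds than are shown below. What is called first, only, known or untested is meant among the compounds shown, and "the series" means these compounds.

Of the compounds shown here, three have been measured so far: compound 1 `COc1cc(/C=N/NC(=O)CCCc2nc3ccccc3c(=O)[nH]2)cc(O)c1O`, compound 2 `O=C(CCc1nc2ccccc2c(=O)[nH]1)N/N=C/c1ccc([N+](=O)[O-])cc1` and compound 3 `COc1ccc(/C=N/NC(=O)CCCc2nc3ccccc3c(=O)[nH]2)cc1`. In a physicochemical assay, read by spectrophotometry, with a stated time of 6 min (a higher number here means a weaker inhibitor, a lower number a stronger inhibitor), compound 1 gives 50000000 nM, compound 2 gives 220000000 nM and compound 3 gives 180000000 nM. Compound 2 thus shows the highest number of the three, within the scatter of compound 3 but clearly beyond it against compound 1. Compound 4 `COc1cc(/C=N/NC(=O)CCc2nc3ccccc3c(=O)[nH]2)ccc1O` is not yet measured. It differs from compound 2 in one place: 4-hydroxy-3-methoxyphenyl in place of 4-nitrophenyl on a carbon with a double bond to nitrogen. For the measured compounds named here, no measured pair shows this exact change, so the expectation is cautious; compound 1, which also carries a hydroxyl on its ring, gives the lowest number so far at 50000000 nM, hinting at a lower number here. Compound 4 is expected to give about 90000000 nM, with a likely range from 30000000 nM to 250000000 nM. The step expected is a 2.4-fold lower number from compound 2 to compound 4 (0.39 log units; beyond the scatter), toward a stronger inhibitor, though possibly not far beyond the scatter.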

Compound 4, half-maximal inhibitory concentration: 95000000 nM
The estimate for compound 4 lay 1.1-fold (0.02 log units) below the measured number, and the stated range covers the measured number.
By their numbers in this assay, from the lowest: compounds 1, 4, 3 and 2 (each within the scatter of the next, the first and the last beyond it).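

In this assay, putting 4-hydroxy-3-methoxyphenyl in place of 4-nitrophenyl on a carbon with a double bond to nitrogen gives a 2.3-fold lower number from compound 2 to compound 4 (0.36 log units; beyond the scatter) and so moves toward a stronger inhibitor. For the compounds shown here, this is the first measured step at this position, and it shows that the group held there can move the number beyond the scatter, though only modestly. On these data alone, it remains open whether the hydroxyl, the methoxy or both account for the step, and whether an amine or a carboxylic acid on that ring would go further. Nothing available explains the step.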